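Methylating the hydroxamic acid nitrogen of a bis-indolyl chain

The source may report more compounds than this note shows. Statements on the series, on what has been measured and on what is new or still open speak of the compounds shown alone.

Measured compounds:
- compound 1, `O=C(CCCC(c1c[nH]c2ccccc12)c1c[nH]c2ccccc12)NO`, > 20000 nM in a functional assay on HCT-116 cells (Homo sapiens) for cytotoxicity, read by sulforhodamine B assay, with a stated time of 24 h; a higher number here means a weaker inhibitor, a lower number a stronger inhibitor
- compound 2, `O=C(CCCCC(c1c[nH]c2ccccc12)c1c[nH]c2ccccc12)NO`, 5800 nM
- compound 3, `Cn1cc(C(CCCCCC(=O)NO)c2cn(C)c3ccccc23)c2ccccc21`, 6600 nM

The value given for compound 1 is a limit of this assay, not a number. Compound 2 and compound 3 both give numbers, and compound 3 stands highest of the two, although its gap to compound 2 lies within the scatter, so no order between them can be claimed. Among the compounds with values here, the one step measured so far, an at least 3.4-fold lower number from compound 1 to compound 2 (0.53 log units; beyond the scatter), concerns the length of the chain that carries the hydroxamic acid and touches the limit described by the limit of > 20000 nM in this assay, at which 1 of the 3 values shown sits.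

Compound 4, `CN(O)C(=O)CCCCCC(c1cn(C)c2ccccc12)c1cn(C)c2ccccc12`, is not yet measured. It differs from compound 3 by methyl in place of hydrogen on an amide-type nitrogen. Within the data shown here, none of the measured steps changes this nitrogen, so nothing here shows how this assay answers to a methyl in place of hydrogen on an amide-type nitrogen. Any expectation therefore rests on compound 3 alone, with wide uncertainty, and there is a real chance that only a limit is reported. Compound 4 is estimated at 18000 nM, within a range from 6000 nM to 50000 nM, which would mean an expected step of a 2.7-fold higher number from compound 3 to compound 4 (0.44 log units; beyond the scatter).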

Compound 4, half-maximal inhibitory concentration: > 20000 nM
Compound 4: no number, only a limit; the forecaster's own chance of this, stated with the estimate: 45%; middle value at least 1.1-fold (0.04 log units) away from the limit.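

This is the first change shown at the hydroxamic acid nitrogen itself; the earlier step concerned only the length of the chain. In this assay, putting methyl in place of hydrogen on this amide-type nitrogen, which turns hydroxycarbamoyl into hydroxy(methyl)carbamoyl, gives an at least 3.0-fold higher number from compound 3 to compound 4 (0.48 log units; beyond the scatter), so in this one pair the hydrogen cannot be swapped for methyl without a clear rise in the number. The true size of the step stays unknown because the result of compound 4 reaches the top of what is reported: the limit of > 20000 nM in this assay, at which 2 of the 4 values shown sit.

From the compounds shown here alone, what remains open is whether this rise comes from the methyl that enters or from the hydrogen that leaves, which an ethyl on the same nitrogen, or a carboxylic acid in place of the hydroxycarbamoyl group, could help to separate. The compounds shown also leave open whether the same change would act alike on a chain of another length or on a core with hydrogen on the ring nitrogens, since a single pair carries this result.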